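The source may hold more compounds than are shown below. What is called first, only, known or untested is meant among the compounds shown, and "the series" means these compounds.

Working notes on the series.

Of the compounds shown here, three have been measured in a functional assay on the whole organism (strain albino) for inhibition, with Rattus norvegicus as the target, read by paw edema, with stated times of 30 min and 1 h, at a dose of 100 mg/kg by the oral route; on this read-out lower numbers stand for less inhibition and higher numbers for more inhibition at the one dose given (going by the name of the read-out). In this assay compound 1 `O=C(CBr)Nc1ccc(C(=O)/C=C/c2ccc(Cl)cc2)cc1` gives 44%. Compound 2 `COc1ccc(/C=C/C(=O)c2ccc(NC(=O)CBr)cc2)cc1` gives 37% in this assay. Compound 3 `CC(O[N+](=O)[O-])C(=O)Nc1ccc(C(=O)/C=C/c2ccc(Cl)cc2)cc1` gives 45% in this assay. Compound 2 differs from compound 1 by methoxy in place of chloro on an aromatic carbon, and the resulting step is a number 7 percentage points lower from compound 1 to compound 2 (within the scatter). The core of compound 3 differs from the core of compound 1 by 1-(nitrooxy)ethyl in place of bromomethyl on a carbonyl carbon, with a step of a number 1 percentage points higher from compound 1 to compound 3 (within the scatter) in this assay. Compound 4 `COc1ccc(/C=C/C(=O)c2ccc(NC(=O)C(C)O[N+](=O)[O-])cc2)cc1` awaits measurement in this assay; it differs from compound 3 by methoxy in place of chloro on an aromatic carbon, the same change at the same place as that from compound 1 to compound 2. Going by that earlier step, the expected step in this assay is a number 7 percentage points lower from compound 3 to compound 4 (within the scatter). The expected value for compound 4 in this assay is 38%, estimated to fall between 28% and 48%.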

Compound 4, a percentage reported as inhibition, in the whole organism at one dose (the size of the read-out at that dose, not a potency): 43%
The estimate for compound 4 lay 5 percentage points below the measured number; the range from low to high includes it.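

In this assay the change from 4-chlorophenyl to 4-methoxyphenyl gives a number 2 percentage points lower from compound 3 to compound 4 (within the scatter), and it carries over between the two cores: the same change on two cores in this assay, a number 7 percentage points lower (within the scatter) from compound 1 to compound 2 and a number 2 percentage points lower (within the scatter) from compound 3 to compound 4, 5 percentage points apart, within the scatter of two such steps. The change from bromomethyl to 1-(nitrooxy)ethyl on a carbonyl carbon gives a number 6 percentage points higher from compound 2 to compound 4 (within the scatter), and it carries over in the same way: the same change on two cores in this assay, a number 1 percentage points higher (within the scatter) from compound 1 to compound 3 and a number 6 percentage points higher (within the scatter) from compound 2 to compound 4, 5 percentage points apart, within the scatter of two such steps. All of these steps lie within the scatter, which means the four compounds show agreement between the two cores at this one dose, but they do not show that either change has an effect of its own or that the steps would hold on a further core.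

Still open, from the compounds shown here alone, is how the read-out responds to an amine or a carboxylic acid in place of chloro, or to a longer chain in place of bromomethyl. Going by these compounds, the response at other doses also remains open.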